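Replacing methyl with cyclopentyl on the shared core

This account rests on a few compounds, and the source may have more. Where it says the series, first, only, none or still open, it means among the compounds named here.

Values so far in an ADME assay on microsomes from liver (Homo sapiens) for metabolic stability, with a stated time of 60 min, tested at 1 uM; a higher number here means that more of the compound is left, a lower number that less of the compound is left
- Compound 1 `COc1cc(-c2cnn3cc(OC)c(-c4cnn(C)c4)nc23)ccn1` gives 43%
- Compound 2 `CNc1nc2c(-c3ccnc(OC)c3)cnn2cc1OC` gives 63%
- Compound 3 `COc1cc(-c2cnn3cc(OC)c(C)nc23)ccn1` gives 44%

Compound 3 lies within the scatter of compound 1, and both fall short of compound 2. The measured step down to compound 3 is a number 19 percentage points lower from compound 2 to compound 3 (beyond the scatter).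

Compound 4 `COc1cc(-c2cnn3cc(OC)c(C4CCCC4)nc23)ccn1` has cyclopentyl in place of methyl on an aromatic carbon.

The measured steps all change this same carbon. Putting methyl in place of 1-methyl-1H-pyrazol-4-yl gave a number 1 percentage points higher from compound 1 to compound 3 (within the scatter), so a ring there does not by itself set the number apart from methyl. Putting methylamino in place of 1-methyl-1H-pyrazol-4-yl gave a number 20 percentage points higher from compound 1 to compound 2 (beyond the scatter), a modest step. Cyclopentyl has no hydrogen-bond donors, so it shares little with the group in compound 2 at 63%. Going by the values given here, no measured compound has a non-aromatic ring here, so the direction remains a judgement. The expected change, of modest size and downward, is a number 17 percentage points lower from compound 3 to compound 4 (beyond the scatter). For compound 4 the estimate is 27%, with an expected range from 8% to 47%.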

Compound 4, percent of the compound remaining: 32%
For compound 4 the middle estimate is 5 percentage points below the measured one, and the stated range covers the measured number.
By their numbers in this assay, from the lowest: compound 4; then compounds 1 and 3 (each within the scatter of the next); then compound 2.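

In this assay this carbon turns out to respond to a non-aromatic ring: compound 4 with cyclopentyl sits apart from the methyl compound (a number 12 percentage points lower from compound 3 to compound 4 (beyond the scatter)) and from the compound with 1-methyl-1H-pyrazol-4-yl (a number 11 percentage points lower from compound 1 to compound 4 (beyond the scatter)), two groups that could not be told apart from each other. The widest gap so far also ends at cyclopentyl (a number 31 percentage points lower from compound 2 to compound 4 (beyond the scatter)), so compound 4 now stands below all three other compounds, each step beyond the scatter. Nothing available explains this drop, so it stands as an observation only.

Still open, going by these compounds, is whether the ring itself or simply the added carbons matter, which cyclopropyl or an open isopropyl chain could help separate. Also open, on these data alone, is whether an amine other than methylamino, such as dimethylamino or morpholine, would match compound 2 at 63%.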